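Swapping an Amide for a Cyclopentyl Ester

The source may report more compounds than this note shows. Statements on the series, on what has been measured and on what is new or still open speak of the compounds shown alone.

Measured in an assay on membranes from HeLa cells for displacement of a labelled ligand from adenosine receptor A3 (Homo sapiens), read by scintillation counting, with a stated time of 180 min, tested at 1 uM; on this read-out lower numbers stand for less inhibition and higher numbers for more inhibition at the one concentration tested (going by the name of the read-out):
compound 1 `CC1=C(C(=O)OCc2ccccc2)C(c2ccco2)NC(=O)N1`: 3%
compound 2 `CCNC(=O)C1=C(C)NC(=O)NC1c1ccco1`: 3%
compound 3 `CCN(CC)C(=O)C1=C(C)NC(=O)NC1c1ccco1`: 19%

Compound 3 stands highest of the three, beyond the scatter above both compound 1 and compound 2, which sit at the same low level. Among the compounds with values here, the one measured step, a number 16 percentage points higher from compound 2 to compound 3 (beyond the scatter), is a modest rise and concerns the amide nitrogen, not the change now made. Compound 4 `CC1=C(C(=O)OC2CCCC2)C(c2ccco2)NC(=O)N1` differs from compound 3 by cyclopentyloxy in place of diethylamino on a carbonyl carbon. Within the data shown here, no measured step bears directly on this swap; the nearest guide is compound 1, which also carries an ester and gives 3% in this assay. Compound 4 is therefore expected to fall back toward that low level, a step of a number 13 percentage points lower from compound 3 to compound 4 (beyond the scatter). The estimate for compound 4 is 6%, with a range from 0% to 20%.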

Compound 4, a percentage reported as inhibition, at one concentration (the size of the read-out at that concentration, not a potency): 14%
Estimate against measurement, compound 4: 8 percentage points below; low and high end bracket the measured number.
By their numbers in this assay, from the lowest: compounds 1 and 2 (each within the scatter of the next); then compounds 4 and 3 (each within the scatter of the next).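

In this assay an ester here is not tied to the low level: cyclopentyl in place of benzyl on an oxygen next to a carbonyl group gives a number 11 percentage points higher from compound 1 to compound 4 (beyond the scatter) as a modest rise. On the carbonyl carbon, cyclopentyloxy reads level with diethylamino, with a number 5 percentage points lower from compound 3 to compound 4 (within the scatter) as the step, and it reads above ethylamino, with a number 11 percentage points higher from compound 2 to compound 4 (beyond the scatter) as a modest step. Nothing at hand explains these differences. On these data alone, how a methyl ester or a carboxylic acid at this carbonyl carbon would read remains open. So does a longer chain on the ester oxygen.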